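This account rests on a few compounds, and the source may have more. Where it says the series, first, only, none or still open, it means among the compounds named here.

The series is followed in a functional assay on A549 cells (Homo sapiens) for antiproliferative activity, read by MTT assay, with a stated time of 72 h; on this read-out higher numbers stand for weaker inhibition and lower numbers for stronger inhibition. Compound 1 `COc1cc2ncnc(Nc3cccc(Cl)c3)c2cc1OCCCCC(=O)Nc1ccc(S(N)(=O)=O)cc1` gives 11200 nM in this assay. Compound 2 `COc1cc2ncnc(Nc3ccc(F)c(Br)c3)c2cc1OCCCCC(=O)Nc1ccc(S(N)(=O)=O)cc1` gives 16000 nM. Within the data shown here, the single change between these two, a 1.4-fold higher number from compound 1 to compound 2 (0.15 log units; within the scatter), is the only measured step so far, and it lies within the scatter. Compound 3 `NS(=O)(=O)c1ccc(NC(=S)Nc2ccc3ncnc(Nc4ccc(F)c(Cl)c4)c3c2)cc1` is reported in this assay only as a limit, > 40000 nM, so no number is known for it. It sits at the limit of > 40000 nM in this assay, at which 1 of the 3 values shown sits.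

Compound 4 `CCc1ccc(Nc2ncnc3ccc(NC(=S)Nc4ccc(S(N)(=O)=O)cc4)cc23)cc1` has not yet been measured in this assay. It differs from compound 3 by 4-ethylphenyl in place of 3-chloro-4-fluorophenyl on a nitrogen on an aromatic ring. Among the measured compounds shown here, this change sits on a nitrogen on an aromatic ring, as did the change from compound 1 to compound 2, but no measured step covers 4-ethylphenyl entering in place of 3-chloro-4-fluorophenyl, and the starting point is a limit rather than a number. For the measured compounds named here, with the one measured step of this kind lying within the scatter, no step beyond the scatter is expected. The step from compound 3 to compound 4 is expected to be a step that the limit leaves unreadable from compound 3 to compound 4. Compound 4 is therefore estimated at 45000 nM, with a range from 15000 nM to 120000 nM, and a limit rather than a number is the more likely report.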

Compound 4, half-maximal inhibitory concentration: 24600 nM
Beside the measured number, compound 4's estimate is 1.8-fold (0.26 log units) above it; measured number inside the range.
By their numbers in this assay, from the lowest: compounds 1, 2 and 4 (each within the scatter of the next, the first and the last beyond it). At a limit, above all of these: compound 3.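

Replacing 3-chloro-4-fluorophenyl with 4-ethylphenyl on a nitrogen on an aromatic ring gives an at least 1.6-fold lower number from compound 3 to compound 4 (0.21 log units; that floor lies within the scatter), and in this assay compound 4 gives 24600 nM. Compound 3 is reported only as a limit, so the floor of this step is all that can be read, and the true size of the step cannot be read: the limit of > 40000 nM in this assay, at which 1 of the 4 values shown sits. The earlier step at this place, a 1.4-fold higher number from compound 1 to compound 2 (0.15 log units; within the scatter), exchanged one halogen-bearing phenyl for another, whereas this change shows that a phenyl with an ethyl group and no halogen, with the same heavy-atom count, still gives a measured number on the core of compound 3.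

As far as these compounds go, it remains open whether the removal of the chlorine and fluorine or the entry of the ethyl group accounts for the change, a question that an unsubstituted phenyl or a 4-methylphenyl on this nitrogen could separate. From the compounds shown here alone, it is also open whether 4-ethylphenyl would behave in the same way on the core of compound 1, and what an amine or a carboxylic acid at the 4-position of this phenyl would give.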